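The compounds below may be only part of what the source reports. "The series", "measured", "known", "first", "only" and "open" are said of these compounds alone.

Three compounds share one core and differ only in the group on the amide-type nitrogen. Compound 1 `CN1CCC(NC(=O)c2cc(-c3ccc(NS(=O)(=O)c4cccc(Cl)c4Cl)cc3)nc3[nH]ncc23)C1` carries a 1-methylpyrrolidin-3-yl there and gives 21 nM in an assay for inhibition of serine/threonine-protein kinase Sgk1 (Homo sapiens), with stated times of 30 min and 60 min, in the presence of a further agent that is not named here; a lower number here means a stronger inhibitor, a higher number a weaker inhibitor. Compound 2 `CNC(=O)c1cc(-c2ccc(NS(=O)(=O)c3cccc(Cl)c3Cl)cc2)nc2[nH]ncc12` carries a methyl instead and gives 929 nM in this assay. Compound 3 `CC(C)NC(=O)c1cc(-c2ccc(NS(=O)(=O)c3cccc(Cl)c3Cl)cc2)nc2[nH]ncc12`, with an isopropyl, gives 17600 nM in this assay. Compound 2 thus stands second highest of the three numbers: compound 3 lies above it by a 19-fold higher number from compound 2 to compound 3 (1.28 log units; beyond the scatter), while compound 1 lies well below it, the step of a 44-fold higher number from compound 1 to compound 2 (1.65 log units; beyond the scatter) being large.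

Compound 4 `CN1CCC(CNC(=O)c2cc(-c3ccc(NS(=O)(=O)c4cccc(Cl)c4Cl)cc3)nc3[nH]ncc23)C1` is compound 2 with 1-methylpyrrolidin-3-yl in place of hydrogen on a saturated chain carbon bound to an amide-type nitrogen; read one bond further out, methyl becomes (1-methylpyrrolidin-3-yl)methyl. Going by the values given here, two measured steps bear on this. The step from compound 1 to compound 2 showed that trading the 1-methylpyrrolidin-3-yl for methyl gave a 44-fold higher number from compound 1 to compound 2 (1.65 log units; beyond the scatter); compound 4 restores that ring, though one bond further from the nitrogen. The step from compound 2 to compound 3 gave a 19-fold higher number from compound 2 to compound 3 (1.28 log units; beyond the scatter), so merely adding carbon at that nitrogen did not help there. A large downward step in this assay is expected, possibly short of a full return to the number of compound 1. Compound 4 is therefore estimated at 60 nM (15 nM to 250 nM), an expected step of a 15-fold lower number from compound 2 to compound 4 (1.19 log units; beyond the scatter).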

Compound 4, half-maximal inhibitory concentration: 45 nM
The estimate for compound 4 lay 1.3-fold (0.12 log units) above the measured number, and the stated range covers the measured number.
By their numbers in this assay, from the lowest: compound 1; then compound 4; then compound 2; then compound 3.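

Compound 4 shows that the 1-methylpyrrolidin-3-yl ring need not sit directly on the amide-type nitrogen to give a low number in this assay: adding it to the saturated chain carbon gives a 21-fold lower number from compound 2 to compound 4 (1.31 log units; beyond the scatter), and exchanging the isopropyl for (1-methylpyrrolidin-3-yl)methyl gives a 390-fold lower number from compound 3 to compound 4 (2.59 log units; beyond the scatter). Setting the ring one bond further out has only a small cost, a 2.1-fold higher number from compound 1 to compound 4 (0.33 log units; beyond the scatter), a modest step, though one beyond the scatter. Going by these compounds alone, no measurement offered here explains why the ring lowers the number so far.

From the compounds shown here alone, whether the gain comes from the ring itself or from its nitrogen stays open, and a cyclopentyl group at this place would separate the two. A longer chain to the same ring, or a piperidine ring in its place, would show how far this tolerance extends.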